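The source may report more compounds than this note shows. Statements on the series, on what has been measured and on what is new or still open speak of the compounds shown alone.

Compounds measured so far:
- Compound 1 `COc1cc([C@](O)(CCN(C)C)[C@@H](c2cc3cc(Br)ccc3nc2OC)c2cccc(OC)c2F)cc(OC(F)F)n1`: 14400 ng.h/mL
- Compound 2 `COc1cc([C@](O)(CCN(C)C)[C@@H](c2cc3cc(C#N)ccc3nc2OC)c2cccc(OC)c2F)cc(SC)n1`: 1100 ng.h/mL
- Compound 3 `COc1cccc([C@H](c2cc3cc(Br)ccc3nc2OC)[C@@](O)(CCN(C)C)c2cc(SC)nc(SC)c2)c1F`: 8400 ng.h/mL

In an ADME assay on the whole organism (Mus musculus, strain CD-1) for pharmacokinetics, at a dose of 10 mg/kg by the oral route (on this read-out higher numbers stand for higher exposure at the dose given and lower numbers for lower exposure), compound 3 gives 8400 ng.h/mL. That is within the scatter of compound 1, as the step shows, a 1.7-fold lower number from compound 1 to compound 3 (0.23 log units; within the scatter), and beyond the scatter above compound 2.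

Compound 4 `COc1cccc([C@H](c2cc3cc(C#N)ccc3nc2OC)[C@@](O)(CCN(C)C)c2cc(SC)nc(SC)c2)c1F` carries cyano in place of bromo on an aromatic carbon. Within the data shown here, the one measured step changes a different group, so it says little here. Among the measured compounds shown here, the only measured compound with cyano is compound 2 at 1100 ng.h/mL, and it also differs from compound 3 elsewhere. On that value, a drop beyond the scatter is expected, an estimated 3.4-fold lower number from compound 3 to compound 4 (0.53 log units; beyond the scatter). Compound 4 is estimated at 2500 ng.h/mL, with an expected range of 800 ng.h/mL to 7000 ng.h/mL.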

Compound 4, area under the concentration-time curve: 1100 ng.h/mL
Compound 4: middle estimate off by 2.3-fold (0.36 log units), on the high side; measured number inside the range.
By their numbers in this assay, from the lowest: compounds 2 and 4 (each within the scatter of the next); then compounds 3 and 1 (each within the scatter of the next).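

In this assay, cyano in place of bromo on an aromatic carbon can now be read alone, and it brings a clear drop (a 7.6-fold lower number from compound 3 to compound 4 (0.88 log units; beyond the scatter)). Compound 2 could not show this, since it differs from compound 3 in a second place. With cyano present, methylsulfanyl in place of methoxy on an aromatic carbon leaves the number unmoved (no change at the digits printed from compound 2 to compound 4 (within the scatter)). Nothing measured here explains the drop. On these data alone, how an amine or a carboxylic acid on this aromatic carbon would compare with bromo and cyano stays open.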